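Swapping 2-(trifluoromethyl)benzyl for 3-fluorobenzyl

A few compounds are considered here, and "the series" means these few. Any claim that something is new, unique, unknown or untested is made for them only; others in the source may bear on it.

Compound 1 `COc1cc(OC)c(-c2coc3cc(OCC=C(C)C)ccc3c2=O)cc1OC`: 3800 nM
Compound 2 `COc1cc(OC)c(-c2coc3cc(OCc4ccccc4C(F)(F)F)ccc3c2=O)cc1OC`: > 10000 nM

These values come from a functional assay on HUVEC cells (Homo sapiens) for antiproliferative activity, read by MTT assay, with a stated time of 24 h; on this read-out higher numbers stand for weaker inhibition and lower numbers for stronger inhibition. Compound 2 gives > 10000 nM, which is a limit and not a number. Compound 3 `COc1cc(OC)c(-c2coc3cc(OCc4cccc(F)c4)ccc3c2=O)cc1OC` carries 3-fluorophenyl in place of 2-(trifluoromethyl)phenyl on a saturated chain carbon bound to an oxygen on an aromatic ring. Going by the values given here, one measured step bears on this place: an at least 2.6-fold higher number from compound 1 to compound 2 (0.42 log units; beyond the scatter). That step shows that a change here can move the number, so a modest move to a lower number is expected for compound 3. The expected step is an at least 1.6-fold lower number from compound 2 to compound 3 (0.22 log units; that floor lies within the scatter). Compound 3 is estimated at 6000 nM, within a range of 2000 nM to 15000 nM.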

Compound 3, half-maximal inhibitory concentration: 5300 nM
Compound 3: the middle estimate sits 1.1-fold (0.05 log units) above what was measured; low and high end bracket the measured number.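

In this assay, compound 3 shows that a benzyl-type group at this place can give a measurable number, and the change from 2-(trifluoromethyl)phenyl to 3-fluorophenyl gives an at least 1.8-fold lower number from compound 2 to compound 3 (0.27 log units; that floor lies within the scatter). Replacing 2-methylprop-1-en-1-yl with 3-fluorophenyl gives a 1.4-fold higher number from compound 1 to compound 3 (0.14 log units; within the scatter), so these two groups cannot be told apart here. The true size of the first step stays unknown, since compound 2 gives only a limit: the limit of > 10000 nM in this assay, at which 1 of the 3 values shown sits.

Still open, going by these compounds, is whether the number follows the fluorine or the removal of trifluoromethyl. Also open, on these data alone, is how an unsubstituted benzyl or an amine-bearing group would read at this place.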